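Amide swap at the furan carbon of compound 2

A few compounds are considered here, and "the series" means these few. Any claim that something is new, unique, unknown or untested is made for them only; others in the source may bear on it.

Compound 2 `CCCNC(=O)c1cccc(-c2cc3c(CN4CCc5cc(OC)c(OC)cc5C4)ccc(OC)c3o2)c1` has in an in vitro assay on COS-7 cells for displacement of a labelled ligand from Alpha-2B adrenergic receptor (Homo sapiens) (a higher number here means a weaker inhibitor, a lower number a stronger inhibitor), only the entry "not determined" (no result reported); the same holds for compound 1 `COc1cc2c(cc1OC)CN(Cc1ccc(OC)c3oc(-c4cccnc4)cc13)CC2`, whose entry in this assay is "not determined" (no result reported), so neither gives a numerical foothold. Among the measured compounds shown here, the only number comes from compound 3 `COc1cc2c(cc1OC)CN(Cc1ccc(OC)c3oc(-c4cccc(C(=O)NCCN(C)C)c4)cc13)CC2`, which in this assay gives 584 nM. For the measured compounds named here, compound 3 shares the core of compound 2 and differs from it only in the tail on the amide, so its value is the nearest anchor, though no step between the two is recorded.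

Compound 4 `COc1cc2c(cc1OC)CN(Cc1ccc(OC)c3oc(C(=O)NCC(C)(C)N)cc13)CC2` is the next candidate. The change from compound 2 is (2-amino-2-methylpropyl)carbamoyl in place of 3-(propylcarbamoyl)phenyl on an aromatic carbon. The aromatic ring that carried the amide in compound 2 is gone, and the amide now sits directly on the five-membered ring; a free amine is added on the chain. Going by the values given here, no measured pair speaks to a change of this kind, so its size cannot be read from the data. The working expectation is a step beyond the usual scatter toward a weaker inhibitor, with the direction left open. Compound 4 is estimated at 1200 nM in this assay, with a plausible range of 200 nM to 6000 nM.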

Compound 4, inhibition constant: 1540 nM
The estimate for compound 4 lay 1.3-fold (0.11 log units) below the measured number; the measured number falls inside the stated range.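

In this assay compound 4 gives 1540 nM, but no new step can be read from it; compound 2 has only the entry "not determined" (no result reported). From the compounds shown here alone, whether exchanging 3-(propylcarbamoyl)phenyl for (2-amino-2-methylpropyl)carbamoyl strengthens or weakens inhibition, and by how much, stays open. Nothing shown here offers an explanation for the value of compound 4.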